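A few compounds are considered here, and "the series" means these few. Any claim that something is new, unique, unknown or untested is made for them only; others in the source may bear on it.

The study compares two measured compounds and looks ahead to a third. Compound 1 `COc1ccc(/C=C/C(=O)Nc2cc(C(=O)c3cc(OC)c(OC)c(OC)c3)ccc2OC)cc1` and compound 2 `COc1ccc(/C=C/C(=O)Nc2cc(C(=O)c3cc(OC)c(OC)c(OC)c3)cc(OC)c2OC)cc1OC` share a common core and were both tested in a functional assay on COLO 205 cells (Homo sapiens) for cytotoxicity, read by MTT assay, with a stated time of 72 h; a higher number here means a weaker inhibitor, a lower number a stronger inhibitor. Compound 1 gives 10900 nM. Compound 2 gives 5700 nM, the lowest of the two numbers, but its nearest neighbour is compound 1 and the gap between them lies within the usual scatter, so the two cannot be ranked against each other. Compound 3 `COc1ccc(/C=C/C(=O)Nc2cc(C(=O)c3cc(OC)c(OC)c(OC)c3)cc(OC)c2OC)cc1` has not yet been measured. It differs from compound 2 in one place: hydrogen in place of methoxy on an aromatic carbon. For the measured compounds named here, no step between measured compounds isolates this change, so no direction can be drawn from the data. Compound 3 is expected to give 7500 nM, with a range from 3000 nM to 18000 nM. The expected step of a 1.3-fold higher number from compound 2 to compound 3 (0.12 log units; within the scatter) is therefore estimated to stay within the scatter.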

Compound 3, half-maximal inhibitory concentration: 4800 nM
For compound 3 the middle estimate is 1.6-fold (0.19 log units) above the measured one; the measured number falls inside the stated range.
By their numbers in this assay, from the lowest: compounds 3, 2 and 1 (each within the scatter of the next, the first and the last beyond it).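

Going from 3,4-dimethoxyphenyl to 4-methoxyphenyl, with hydrogen in place of methoxy ortho to a methoxy group, gives a 1.2-fold lower number from compound 2 to compound 3 (0.07 log units; within the scatter) in this assay, so this methoxy can go without a change that the assay can distinguish. For the compounds shown here, the other change, methoxy in place of hydrogen on an aromatic carbon, gives a 2.3-fold lower number from compound 1 to compound 3 (0.36 log units; beyond the scatter) and is a modest step, the only single change here that exceeds the scatter. Nothing measured on these compounds offers an explanation for either step.

From the compounds shown here alone, whether the position tolerates groups other than hydrogen and methoxy remains open, for example a hydroxyl, an amine or an ethoxy chain. Going by these compounds, it also remains open whether a single fluorine atom there would behave as hydrogen does.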